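The source may hold more compounds than are shown below. What is called first, only, known or untested is meant among the compounds shown, and "the series" means these compounds.

Of the compounds shown here, two built on a shared core have been tested for cytotoxicity. Compound 1 `COc1nc(OC)nc(Sc2cccc(I)c2C#N)n1` gives 30500 nM in an ADME assay on HEK-293T cells (Homo sapiens) for cytotoxicity, read by MTT assay, with a stated time of 48 h; on this read-out higher numbers stand for lower toxicity in this test and lower numbers for higher toxicity in this test. Compound 2 `COc1nc(OC)nc(Sc2ccc(F)cc2C#N)n1` reaches only the limit of this test, > 200000 nM, so for it the assay reports no number (the limit of > 200000 nM in this assay, at which 1 of the 2 values shown sits). Compound 3 `COc1nc(OC)nc(Sc2ccc(Br)cc2C#N)n1` has not yet been tested. It differs from compound 2 in one place: bromo in place of fluoro on an aromatic carbon. No measured pair among these compounds shares that change, so the size of the step can only be estimated. Because compound 2 stands at the limit (the limit of > 200000 nM in this assay, at which 1 of the 2 values shown sits), any change can only appear as a move toward higher toxicity, or as another limit. The expectation is a moderate step of an at least 2.0-fold lower number from compound 2 to compound 3 (0.30 log units; that floor lies within the scatter) toward higher toxicity in this assay, somewhat beyond the scatter. Compound 3 is therefore expected to give about 100000 nM, within a range from 40000 nM to 200000 nM.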

Compound 3, half-maximal cytotoxic concentration: 53500 nM
Beside the measured number, compound 3's estimate is 1.9-fold (0.27 log units) above it; the range from low to high includes it.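

Exchanging fluoro for bromo on this aromatic carbon, meta to a cyano group and para to a large group, gives a step that can be read in this assay: an at least 3.7-fold lower number from compound 2 to compound 3 (0.57 log units; beyond the scatter). This shows that a change of this one substituent at this position is enough to move the read-out toward higher toxicity, by more than the usual scatter of the test. The true size of the step may be larger, because the value of compound 2 is a limit and not a number: the limit of > 200000 nM in this assay, at which 1 of the 3 values shown sits.

As far as these compounds go, with only fluoro and bromo compared here, it remains open whether chloro at this position would give a value between theirs. From the compounds shown here alone, it is also open whether a group of a different kind there, such as an amine or a carboxylic acid, would move the read-out in the same direction.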